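Methyl to Ethyl: Expected Effect on Receptor Binding

A few compounds are considered here, and "the series" means these few. Any claim that something is new, unique, unknown or untested is made for them only; others in the source may bear on it.

Measured compounds:
compound 1, `Cc1cc(CN(CC2CCCC2)C(CC(=O)O)c2ccc(Cl)cc2)ccc1OCCN1C(=O)CCC1=O`, gives 71 nM in an assay on CHO cells for displacement of a labelled ligand from C-X-C chemokine receptor type 3 (Homo sapiens), with a stated time of 60 min; a higher number here means a weaker inhibitor, a lower number a stronger inhibitor
compound 2, `Cc1cc(CN(CC2CCCC2)[C@@H](CC(=O)O)c2ccc(Cl)cc2)ccc1OCCN1C(=O)CCC1=O`, gives 36 nM in this assay

Compounds 1 and 2 share every atom and bond; the only difference is that a stereocentre on a saturated chain carbon is drawn without configuration in compound 1 and as S in compound 2. The step of a 2.0-fold lower number from compound 1 to compound 2 (0.29 log units; within the scatter) is small, and the most likely reading is that it reflects the fact that one of compounds 1 and 2 is drawn with a defined configuration and the other without, at the place where they differ rather than any change in the molecule itself. Going by the values given here, compound 2 has the lowest number of the two, with compound 1 its only neighbour, and the two sit within the scatter of each other.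

Compound 3, `CCc1cc(CN(CC2CCCC2)[C@@H](CC(=O)O)c2ccc(Cl)cc2)ccc1OCCN1C(=O)CCC1=O`, differs from compound 2 by methyl in place of hydrogen on a saturated chain carbon bound to an aromatic carbon. Among the compounds with values here, no measured step touches this position, so nothing among the numbers argues for a shift in either direction. The expectation for compound 3 is therefore a step of a 1.1-fold higher number from compound 2 to compound 3 (0.05 log units; within the scatter), that is, nothing beyond the scatter. Compound 3 is expected to give about 40 nM in this assay, with a plausible range from 15 nM to 110 nM.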

Compound 3, half-maximal inhibitory concentration: 31 nM
For compound 3 the middle estimate is 1.3-fold (0.11 log units) above the measured one; the measured number falls inside the stated range.
By their numbers in this assay, from the lowest: compounds 3, 2 and 1 (each within the scatter of the next, the first and the last beyond it).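

Going by these compounds alone, this is the first measured look at this position. In this assay, methyl in place of hydrogen on a saturated chain carbon bound to an aromatic carbon, which turns a methyl group into an ethyl group, gives a 1.2-fold lower number from compound 2 to compound 3 (0.06 log units; within the scatter). The numbers of the two compounds therefore cannot be told apart, so this position takes the one extra carbon without a shift that repeated measurements could distinguish from ordinary variation. Within the data shown here, nothing available explains this outcome, since the only information offered on a possible cause concerns a different pair of compounds and a different place in the molecule.

Going by these compounds, a single step shows how one small change behaves, not how far this position can be altered, so it remains open whether a longer chain such as propyl, or a group carrying oxygen such as hydroxymethyl or methoxy, would give a number beyond the scatter. On these data alone, it also remains open whether an amine at this position would read the same way, and whether the methyl-to-ethyl result would hold on a core with any other change.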